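Methoxy in place of chloro: what solubility to expect

The compounds below may be only part of what the source reports. "The series", "measured", "known", "first", "only" and "open" are said of these compounds alone.

Of the compounds shown here, three sharing one core have been measured in a physicochemical assay for solubility, at pH 7.4; a higher number here means a more soluble compound, a lower number a less soluble compound. Compound 1 `CC(C)Nc1nc(NCc2ccco2)c2ccccc2n1` carries hydrogen at the position in question; in this assay compound 1 gives >= 30000 nM, which is a limit of the assay rather than a number. Compound 2 `CCCCNc1nc(NCc2ccccc2)nc2ccccc12` differs from the others in more than one place; in this assay compound 2 gives <= 10000 nM, again a limit. Compound 3 `CC(C)Nc1nc(NCc2ccco2)c2cc(Cl)ccc2n1` is the chloro analogue of compound 1, and in this assay compound 3 gives <= 20000 nM, also a limit. Compound 3 therefore stands only as a bound, and all three values shown are bounds (the limit of <= 10000 nM in this assay, at which 1 of the 3 values shown sits, (the limit of <= 20000 nM in this assay, at which 1 of the 3 values shown sits), (the limit of >= 30000 nM in this assay, at which 1 of the 3 values shown sits)). Among the compounds with values here, the one step measured in a single place, an at least 1.5-fold lower number from compound 1 to compound 3 (0.17 log units; that floor lies within the scatter), records chloro against hydrogen.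

Compound 4 `COc1ccc2nc(NC(C)C)nc(NCc3ccco3)c2c1` is the next step: methoxy in place of chloro on an aromatic carbon. The step from compound 1 to compound 3 bears on it: the chloro introduced there is the group that now leaves, while the methoxy that enters has no measured precedent among these compounds. The account therefore expects the number to move back up, by an estimated at least 1.2-fold higher number from compound 3 to compound 4 (0.09 log units; that floor lies within the scatter), with wide uncertainty. For compound 4 the estimate is 25000 nM, expected to lie between 10000 nM and 60000 nM.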

Compound 4, solubility: >= 30000 nM
Compound 4 gave a limit, no number; the forecaster's own chance of this, stated with the estimate: 40%; middle value at least 1.2-fold (0.07 log units) away from the limit.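

In this assay, within the data shown here, methoxy in place of chloro on this aromatic carbon gives an at least 1.5-fold higher number from compound 3 to compound 4 (0.17 log units; that floor lies within the scatter), and this is the first group other than hydrogen and chloro seen at this position. Compound 4 gives >= 30000 nM, which is a limit of the assay and not a number. The position therefore takes an oxygen-linked group with the reading at the same limit as the compound carrying hydrogen, but the step from compound 1 to compound 4 cannot be read, as the two values mark only a shared limit: the limit of >= 30000 nM in this assay, at which 2 of the 4 values shown sit.

From the compounds shown here alone, how far compound 1 and compound 4 each lie beyond that limit stays open, and so does the true size of the step away from chloro, whose printed floor is all that can be stated. Also open, going by these compounds, is whether another group on this aromatic carbon, such as an amine, a carboxylic acid or a longer chain like ethoxy, would give a reading that is a number rather than a limit.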